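Triazole series: aryl on ring nitrogen, cytotoxicity notes

The source may hold more compounds than are shown below. What is called first, only, known or untested is meant among the compounds shown, and "the series" means these compounds.

Compound 3 `COc1ccccc1-n1nc(-c2ccc(C(F)(F)F)cc2O)nc1-c1ccccc1O` gives 96.2% in a functional assay on PC-12 cells (Rattus norvegicus) for cytotoxicity, read by MTT assay, with stated times of 2 h and 24 h, tested at 10 uM; a lower number here means a weaker effect, a higher number a stronger effect of the compound at the concentration tested. Among the three measured compounds it stands second highest. Its nearest neighbour is compound 2 `Oc1cc(C(F)(F)F)ccc1-c1nc(-c2ccccc2O)n(-c2ccc(Cl)cc2)n1`, which in this assay gives 96.1%; the step of a number 0.1 percentage points higher from compound 2 to compound 3 (within the scatter) lies within the scatter. The furthest is compound 1 `CCc1ccc(-n2nc(-c3ccc(C(F)(F)F)cc3O)nc2-c2ccccc2O)cc1`, which in this assay gives 107%; the step of a number 10.8 percentage points lower from compound 1 to compound 3 (beyond the scatter) is beyond the scatter, as is a number 10.9 percentage points lower from compound 1 to compound 2 (beyond the scatter).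

Compound 4 `Oc1cc(C(F)(F)F)ccc1-c1nc(-c2ccccc2O)n(-c2cc(F)cc(F)c2)n1` differs from compound 3 in one place: 3,5-difluorophenyl in place of 2-methoxyphenyl on an aromatic nitrogen. Two measured steps exchange the group on this same aromatic nitrogen, a number 10.8 percentage points lower from compound 1 to compound 3 (beyond the scatter) and a number 0.1 percentage points higher from compound 2 to compound 3 (within the scatter). An exchange here has therefore moved the number either modestly downward or not at all. For the measured compounds named here, no measured step sets 2-methoxyphenyl against 3,5-difluorophenyl, so the direction for compound 4 is open. For compound 4 the expected step is a number 0.8 percentage points higher from compound 3 to compound 4 (within the scatter), within the scatter. Compound 4 is estimated at 97% in this assay, with a range from 85% to 110%.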

Compound 4, a percentage reported as activity, at one concentration (the size of the read-out at that concentration, not a potency): 106%
The estimate for compound 4 lay 9 percentage points below the measured number; the range from low to high includes it.
By their numbers in this assay, from the lowest: compounds 2, 3, 4 and 1 (each within the scatter of the next, the first and the last beyond it).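

In this assay, for the compounds shown here, the exchange on this aromatic nitrogen gives a number 9.8 percentage points higher from compound 3 to compound 4 (within the scatter) and a number 9.9 percentage points higher from compound 2 to compound 4 (within the scatter) while a number 1 percentage points lower from compound 1 to compound 4 (within the scatter) shows that 3,5-difluorophenyl is the first group here whose step from 4-ethylphenyl stays within the scatter. Compound 4 therefore lies within the scatter of all three earlier compounds, and the gap between compound 1 and the pair of compound 2 and compound 3 no longer divides the groups on this nitrogen into two separate sets. No measured evidence bears on a cause for these steps.

Going by these compounds, all four groups on this nitrogen are substituted phenyl rings, so the effect of an amine or a carboxylic acid on that phenyl ring, or of a longer alkyl chain in its place, stays open. On these data alone, the response to changes elsewhere on the shared core also stays open.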